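The source may hold more compounds than are shown below. What is called first, only, known or untested is meant among the compounds shown, and "the series" means these compounds.

Measured in a functional assay on SGC-7901 cells (Homo sapiens) for cytotoxicity, read by MTT assay, with a stated time of 38 h; a higher number here means a weaker inhibitor, a lower number a stronger inhibitor:
compound 1 `COc1cc(OC)c2c(=O)c(OCC(=O)N/N=C/c3ccccc3F)c(-c3cc(OC)c(OC)c(OC)c3)oc2c1`: 7720 nM
compound 2 `COc1cc(OC)c2c(=O)c(OCCCCN3CCCCC3)c(-c3cc(OC)c(OC)c(OC)c3)oc2c1`: 6080 nM

The two numbers lie together: a 1.3-fold lower number from compound 1 to compound 2 (0.10 log units; within the scatter). Compound 3 `CCN(CC)CCCOc1c(-c2cc(OC)c(OC)c(OC)c2)oc2cc(OC)cc(OC)c2c1=O` is unmeasured. It differs from compound 2 as follows: diethylamino in place of (piperidin-1-yl)methyl on a saturated chain carbon, three bonds along the chain from an oxygen on an aromatic ring. The exchange, diethylamino in place of (piperidin-1-yl)methyl, sits on a saturated chain carbon, three bonds along the chain from an oxygen on an aromatic ring. For the measured compounds named here, no measured pair makes this exchange, so the single measured step bears on it only loosely, and that step stayed within the scatter. No step beyond the scatter is therefore expected in this assay, the estimated step being a 1.0-fold lower number from compound 2 to compound 3 (0.01 log units; within the scatter). For compound 3 the estimated value is 6000 nM, with an expected range of 2500 nM to 14000 nM.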

Compound 3, half-maximal inhibitory concentration: 56900 nM
Compound 3: the middle estimate sits 9.5-fold (0.98 log units) below what was measured, outside the stated range (above it).
By their numbers in this assay, from the lowest: compounds 2 and 1 (each within the scatter of the next); then compound 3.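

In this assay this position proves sensitive to the side chain: diethylamino in place of (piperidin-1-yl)methyl, three bonds along the chain from the oxygen on the aromatic ring, gives a 9.4-fold higher number from compound 2 to compound 3 (0.97 log units; beyond the scatter), whereas the earlier step stayed within the scatter. The hydrazone-bearing side chain of compound 1 also separates from compound 3, with a 7.4-fold higher number from compound 1 to compound 3 (0.87 log units; beyond the scatter). No evidence on the cause of these steps is at hand.

The step from the 4-(piperidin-1-yl)butyl chain to the 3-(diethylamino)propyl chain changes both the amine and the chain, and the compounds shown do not separate the two. A 3-(piperidin-1-yl)propyl or a 4-(diethylamino)butyl chain would bear directly on this.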